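This account rests on a few compounds, and the source may have more. Where it says the series, first, only, none or still open, it means among the compounds named here.

Measured so far in a functional assay on DU-145 cells (Homo sapiens) for antiproliferative activity, read by MTT assay, with a stated time of 24 h; a higher number here means a weaker inhibitor, a lower number a stronger inhibitor:
compound 1, `COc1cc(C(=O)/C=C/c2cc(-c3cc(OC)c(OC)c(OC)c3)n3nc(-c4ccccc4)cc3n2)cc(OC)c1OC`, gives 34900 nM;
compound 2, `COc1ccc(-c2cc(/C=C/C(=O)c3cc(OC)c(OC)c(OC)c3)nc3cc(-c4ccccc4)nn23)cc1OC`, gives 8300 nM;
compound 3, `COc1ccc(-c2cc(/C=C/C(=O)c3ccccc3)nc3cc(-c4ccccc4)nn23)cc1`, gives 13700 nM.

Compound 4, `COc1ccc(-c2cc(/C=C/C(=O)c3ccccc3)nc3cc(-c4ccccc4)nn23)cc1OC`, is not yet measured. The change from compound 3 to compound 4 is methoxy in place of hydrogen on an aromatic carbon. Within the data shown here, the one measured example of this change is from compound 2 to compound 1, (methoxy in place of hydrogen on an aromatic carbon), where the step was a 4.2-fold higher number from compound 2 to compound 1 (0.62 log units; beyond the scatter). The surroundings are not identical: in compound 2 the carbon is also meta to a methoxy group, so the two are the same kind of change, not the same. How the cores of compound 2 and compound 3 differ is not broken down here; their two values lie within the scatter of each other.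

Among the measured compounds shown here, compound 4 is expected to show a step of a 1.3-fold higher number from compound 3 to compound 4 (0.12 log units; within the scatter), smaller than the earlier one, because the only precedent a 4.2-fold higher number from compound 2 to compound 1 (0.62 log units; beyond the scatter) sits in a different surrounding. Compound 4 is estimated at 18000 nM, expected between 7000 nM and 45000 nM.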

Compound 4, half-maximal inhibitory concentration: 10000 nM
Compound 4: the middle estimate sits 1.8-fold (0.26 log units) above what was measured; the measured number falls inside the stated range.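

In this assay, methoxy in place of hydrogen on an aromatic carbon does not carry over as a fixed step from one core to another: the same change on two cores in this assay, a 4.2-fold higher number (0.62 log units; beyond the scatter) from compound 2 to compound 1 and a 1.4-fold lower number (0.14 log units; within the scatter) from compound 3 to compound 4, 5.8-fold (0.76 log units) apart, beyond the scatter of two such steps. The new step, a 1.4-fold lower number from compound 3 to compound 4 (0.14 log units; within the scatter), lies within the scatter, as does the exchange of 3,4,5-trimethoxyphenyl for phenyl on the carbonyl carbon, a 1.2-fold higher number from compound 2 to compound 4 (0.08 log units; within the scatter). With a single pair on each core, this shows that the step is not transferable between these two settings, but not which difference between them accounts for the gap, nor how the change would behave on any further core.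

Going by these compounds, the effect of a hydroxyl group or an amine on the same aromatic carbon remains open. So does that of a carboxylic acid on the phenyl at the carbonyl carbon.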